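Thiophen-2-yl in place of 4-methylphenyl: expected cytotoxicity

A few compounds are considered here, and "the series" means these few. Any claim that something is new, unique, unknown or untested is made for them only; others in the source may bear on it.

Compound 2 `CCS[C@@H]1[C@H](SCC)[C@@H](Cn2cc(-c3ccc(C)cc3)nn2)O[C@H]1n1ccc(=O)[nH]c1=O` gives 46700 nM in a functional assay on HeLa cells (Homo sapiens) for cytotoxicity, read by MTT assay, with a stated time of 72 h (a higher number here means that more compound is needed for the effect, a lower number that less compound is needed), the higher of the two numbers shown, although the step of a 1.4-fold higher number from compound 1 to compound 2 (0.15 log units; within the scatter) from compound 1 `CCS[C@@H]1[C@H](SCC)[C@@H](Cn2cc(-c3ccccc3C(F)(F)F)nn2)O[C@H]1n1ccc(=O)[nH]c1=O`, which gives 32800 nM, stays within the scatter. Compound 3 `CCOC(=O)c1cn(C[C@H]2O[C@@H](n3ccc(=O)[nH]c3=O)[C@H](SCC)[C@@H]2SCC)nn1` reaches only the limit >= 100000 nM in this assay. The steps of an at least 3.0-fold higher number from compound 1 to compound 3 (0.48 log units; beyond the scatter) and an at least 2.1-fold higher number from compound 2 to compound 3 (0.33 log units; beyond the scatter) both go beyond the scatter, their size bounded by the limit of >= 100000 nM in this assay, at which 1 of the 3 values shown sits. Compound 4 `CCS[C@@H]1[C@H](SCC)[C@@H](Cn2cc(-c3cccs3)nn2)O[C@H]1n1ccc(=O)[nH]c1=O` differs from compound 2 by thiophen-2-yl in place of 4-methylphenyl on an aromatic carbon. One aromatic ring replaced by another gave a 1.4-fold higher number from compound 1 to compound 2 (0.15 log units; within the scatter), within the scatter; only the exchange of the ring for ethoxycarbonyl moved beyond it. The expected step of a 1.1-fold higher number from compound 2 to compound 4 (0.03 log units; within the scatter) is therefore within the scatter, without clear direction. Compound 4 is estimated at 50000 nM, between 25000 nM and 100000 nM.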

Compound 4, half-maximal effective concentration: >= 100000 nM
Compound 4: a limit, no number (the forecaster's own chance of this, stated with the estimate: 25%); middle value at least 2.0-fold (0.30 log units) from the limit.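

Exchange of one aromatic ring for another at this carbon is not always neutral in this assay: thiophen-2-yl moves the number beyond the scatter both against 4-methylphenyl (an at least 2.1-fold higher number from compound 2 to compound 4 (0.33 log units; beyond the scatter)) and against 2-(trifluoromethyl)phenyl (an at least 3.0-fold higher number from compound 1 to compound 4 (0.48 log units; beyond the scatter)). The within-scatter step between the two substituted six-membered rings therefore does not extend to this five-membered ring, and compound 4 joins compound 3 at the assay limit: the limit of >= 100000 nM in this assay, at which 2 of the 4 values shown sit. The step between compound 3 and compound 4 cannot be read, both values being limits.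

From the compounds shown here alone, whether ring size or the sulfur atom drives the loss stays open. A furan-2-yl or an unsubstituted phenyl at this carbon would separate the two.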